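The compounds below may be only part of what the source reports. "The series", "measured", "known", "first", "only" and "open" are said of these compounds alone.

Three pyrazoline compounds built on a shared core are compared here in a functional assay on Caco-2 cells (Homo sapiens) for antiproliferative activity, read by MTT assay, with a stated time of 24 h; on this read-out lower numbers stand for stronger inhibition and higher numbers for weaker inhibition. Compound 1, with structure `COc1cc(C2CC(c3ccccc3)=NN2c2ccc(-c3ccccc3)nn2)cc(OC)c1OC`, carries an unsubstituted phenyl group at one end. In this assay compound 1 gives > 100000 nM, which is a limit of the assay and not a number. Compound 2, `COc1cc(C2CC(c3ccc(Cl)cc3)=NN2c2ccc(-c3ccccc3)nn2)cc(OC)c1OC`, differs from compound 1 by chloro in place of hydrogen on an aromatic carbon. In this assay compound 2 gives > 100000 nM, again a limit rather than a number. The step that the two limits leave unreadable from compound 1 to compound 2 therefore cannot be read in size. Compound 3, `COc1ccc(C2=NN(c3ccc(-c4ccccc4)nn3)C(c3ccccc3)C2)cc1`, rests on a different core from compound 1; the difference between the two cores is not broken down here. In this assay compound 3 gives > 100000 nM, also a limit of the assay.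

Compound 4, `COc1ccc(C2=NN(c3ccc(-c4ccccc4)nn3)C(c3ccc(Cl)cc3)C2)cc1`, is not yet measured. It differs from compound 3 by chloro in place of hydrogen on an aromatic carbon, and the place of the change reads the same as for the step from compound 1 to compound 2, so it is the same change made on the other core. All three measured values sit at the limit of > 100000 nM in this assay, at which 3 of the 3 values shown sit. Because the limit of > 100000 nM in this assay, at which 3 of the 3 values shown sit, is where compound 1, compound 2 and compound 3 all stand, compound 4 is expected to show a step that the limit leaves unreadable from compound 3 to compound 4 that likewise stays unreadable at the limit. The expected value for compound 4 in this assay is therefore 200000 nM, with an estimated range from 60000 nM to 1000000 nM.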

Compound 4, half-maximal inhibitory concentration: > 100000 nM
Compound 4: no number, only a limit (the forecaster's own chance of this, stated with the estimate: 85%); the middle value lies beyond the limit too.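

In this assay compound 4 gives > 100000 nM, which is a limit of the assay and not a number. Among the compounds shown here, the change from compound 3 to compound 4 therefore yields no step that can be read in size: the limit of > 100000 nM in this assay, at which 4 of the 4 values shown sit. The compounds shown leave open whether chloro in place of hydrogen on an aromatic carbon makes any difference on either core.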